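Trifluoromethyl Hydrate Amides Tested on Colon Carcinoma Cells

This account rests on a few compounds, and the source may have more. Where it says the series, first, only, none or still open, it means among the compounds named here.

Compound 1, `CC(=O)c1ccc(NC(=O)CCCCCCNC(=O)C(O)(O)C(F)(F)F)cc1`, gives 12100 nM.
Compound 2, `O=C(CCCCCCNC(=O)C(O)(O)C(F)(F)F)Nc1ccc(S(F)(F)(F)(F)F)cc1`, gives 9110 nM.
Compound 3, `O=C(CCCCCCNC(=O)C(O)(O)C(F)(F)F)Nc1ccc(C(=O)c2ccccc2)cc1`, gives only a limit of > 40000 nM.

In a functional assay on HCT-116 cells (Homo sapiens) for inhibition, read by colorimetric assay, with a stated time of 3 days (on this read-out lower numbers stand for stronger inhibition and higher numbers for weaker inhibition), compound 1 stands highest of the two numbers shown; compound 2 is nearest, with a 1.3-fold lower number from compound 1 to compound 2 (0.12 log units; within the scatter). Compound 3 sits at the limit (the limit of > 40000 nM in this assay, at which 1 of the 3 values shown sits).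

Compound 4, `O=C(CCCCCCNC(=O)C(O)(O)C(F)(F)F)Nc1ccccc1Br`, differs from compound 1 by 2-bromophenyl in place of 4-acetylphenyl on an amide-type nitrogen. Within the data shown here, no measured step changes the whole anilide group in this way. The step of a 1.3-fold lower number from compound 1 to compound 2 (0.12 log units; within the scatter) swaps one group for another on an aromatic carbon without leaving the scatter, while the step of an at least 3.3-fold higher number from compound 1 to compound 3 (0.51 log units; beyond the scatter) enlarges that group and weakens inhibition. Compound 4 carries a smaller group than compound 3 and so is not expected to follow compound 3 to the limit. Compound 4 is therefore expected to show a step of a 1.2-fold higher number from compound 1 to compound 4 (0.06 log units; within the scatter), within the scatter or a little weaker. The estimate for compound 4 is 14000 nM, with a range from 5000 nM to 40000 nM.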

Compound 4, half-maximal inhibitory concentration: 14500 nM
Compound 4: middle estimate off by 1.0-fold (0.02 log units), on the low side; low and high end bracket the measured number.
By their numbers in this assay, from the lowest: compounds 2, 1 and 4 (each within the scatter of the next). At a limit, above all of these: compound 3.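

In this assay, exchanging the whole group on the amide-type nitrogen, with 2-bromophenyl in place of 4-acetylphenyl, gives a 1.2-fold higher number from compound 1 to compound 4 (0.08 log units; within the scatter). Among these compounds, the entering group has no hydrogen-bond acceptor and no carbonyl, so in this pair neither feature of the 4-acetylphenyl group is needed for a number in this range, which the earlier compounds, all bearing a group at the 4-position of the phenyl ring, could not show. Compound 3, with its limit, remains the only compound not read as a number: the limit of > 40000 nM in this assay, at which 1 of the 4 values shown sits.

This one step changes both the substituent and its name-given place on the ring, and it cannot separate the two. On these data alone, how an amine or a carboxylic acid on the phenyl ring, or a longer chain in the core, would read in this assay stays open.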